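Allyl series: replacing the ring on the aromatic nitrogen

The source may hold more compounds than are shown below. What is called first, only, known or untested is meant among the compounds shown, and "the series" means these compounds.

Measured so far:
compound 1, `CCn1c(=O)n(C2OC(CO)[C@@H](O)[C@H]2O)c2nc(N)nc(O)c21`: 15 uM
compound 2, `NCC(O)Cn1c(=O)n(C2OC(CO)[C@@H](O)[C@H]2O)c2nc(N)nc(O)c21`: 28 uM
compound 3, `C=CCn1c(=O)n(C2C=CC(CO)O2)c2nc(N)nc(O)c21`: 6 uM

All three were tested in a functional assay (B cells) with Mus musculus as the target; a lower number here means that less compound is needed, a higher number that more compound is needed for the effect. Compound 3 stands lowest of the three numbers; compound 1 is nearest, and compound 2 furthest, both beyond the scatter. Going by the values given here, the only single-point step recorded is a 1.9-fold higher number from compound 1 to compound 2 (0.27 log units; within the scatter), which concerns the chain on the saturated carbon, not the ring on the aromatic nitrogen, and so does not bear on the present change.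

Compound 4, `C=CCn1c(=O)n([C@H]2CO[C@@H](CO)C2)c2nc(N)nc(O)c21`, differs from compound 3 in one place: a group of 7 heavy atoms (5 carbon, 2 oxygen; one five-membered non-aromatic ring with 1 hetero atom) in place of a group of 7 heavy atoms (5 carbon, 2 oxygen; one five-membered non-aromatic ring with 1 hetero atom), on an aromatic nitrogen. The group that leaves carries a double bond outside aromatic rings; the group that enters carries none and has two defined stereocentres. Among the compounds with values here, no measured pair in the set isolates this exchange, so the direction cannot be anchored to a recorded step. The expectation for this assay is a small shift, a 1.7-fold higher number from compound 3 to compound 4 (0.22 log units; within the scatter), not clearly beyond the scatter. Compound 4 is therefore estimated at 10 uM, with a range of 3 uM to 40 uM.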

Compound 4, concentration for half-maximal effect: 83 uM
Compound 4: middle estimate off by 8.3-fold (0.92 log units), on the low side, and the stated range ends below it.
By their numbers in this assay, from the lowest: compound 3; then compounds 1 and 2 (each within the scatter of the next); then compound 4.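

In this assay, a 14-fold higher number from compound 3 to compound 4 (1.14 log units; beyond the scatter), so the group on this aromatic nitrogen strongly affects the read-out, which the earlier step on the saturated chain could not show. The two groups have the same heavy-atom composition, the same five-membered non-aromatic ring and the same hydrogen-bond donor and acceptor counts, so those shared features alone do not set the number. No measurement shown here explains the size of this step.

The double bond outside aromatic rings leaves and the defined stereocentres enter in the same exchange, so the compounds shown cannot separate their contributions. Also open, on these data alone, is how this position would respond to a ring bearing an amine in place of the hydroxymethyl group, or to a cyclopentane ring with no ring oxygen.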